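This account rests on a few compounds, and the source may have more. Where it says the series, first, only, none or still open, it means among the compounds named here.

Working notes on the series, step from compound 2 to compound 3.

Among the compounds with values here, compound 2 `COc1ccc(Br)c(-c2nc3cc(Cl)ccc3[nH]2)c1O` and compound 1 `COc1ccc(Br)c(-c2nc3ccccc3[nH]2)c1O` are the only two members measured so far. In an assay for inhibition of Alpha amylase (Homo sapiens), with a stated time of 10 min (a higher number here means a weaker inhibitor, a lower number a stronger inhibitor), compound 2 gives 2210 nM, and compound 1 gives 2480 nM; the step of a 1.1-fold lower number from compound 1 to compound 2 (0.05 log units; within the scatter) places the two numbers within the scatter of each other, so compound 2 stands level with compound 1 rather than apart from it.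

Compound 3 `COc1ccc(Br)c(-c2nc3cc([N+](=O)[O-])ccc3[nH]2)c1O` is the next member to go into this assay. Its difference from compound 2 is nitro in place of chloro on an aromatic carbon. Within the data shown here, the only measured step that bears on this change is the one from compound 1 to compound 2, where chloro entered in place of hydrogen, and that step was a 1.1-fold lower number from compound 1 to compound 2 (0.05 log units; within the scatter), within the scatter. Among the measured compounds shown here, no measured compound carries a nitro group, so nothing on hand speaks to its effect one way or the other. On that basis the expectation for compound 3 is no step beyond the scatter, a 1.0-fold lower number from compound 2 to compound 3 (0.00 log units; within the scatter). The estimated value for compound 3 in this assay is therefore 2200 nM, with a range from 900 nM to 5500 nM.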

Compound 3, half-maximal inhibitory concentration: 2290 nM
Beside the measured number, compound 3's estimate is 1.0-fold (0.02 log units) below it; the range from low to high includes it.
By their numbers in this assay, from the lowest: compounds 2, 3 and 1 (each within the scatter of the next).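

In this assay, nitro in place of chloro gives a 1.0-fold higher number from compound 2 to compound 3 (0.02 log units; within the scatter) and nitro in place of hydrogen gives a 1.1-fold lower number from compound 1 to compound 3 (0.03 log units; within the scatter), so hydrogen, chloro and nitro on this aromatic carbon now all stand within the scatter of one another. The level result seen so far with a single heavy atom entering at this position therefore also holds for a group of 3 heavy atoms with 2 hydrogen-bond acceptors and 1 double bond outside aromatic rings, and the three compounds do not separate. Nothing on hand offers an explanation for this level result.

Whether the position stays just as level with an amine, a carboxylic acid or a longer chain remains open, since the three groups shown span only hydrogen, chloro and nitro. Only this one aromatic carbon varies among compound 1, compound 2 and compound 3, so what changes elsewhere on the shared core would do in this assay is also unanswered.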